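Benzylcoumarin series: cytotoxicity notes ahead of compound 4

A few compounds are considered here, and "the series" means these few. Any claim that something is new, unique, unknown or untested is made for them only; others in the source may bear on it.

Measured so far:
compound 1, `Cc1c(Cc2ccccc2)c(=O)oc2cc(OCC(O)CNCCCO)ccc12`, 53400 nM
compound 2, `Cc1c(Cc2ccccc2)c(=O)oc2cc(OCC(O)CNc3nccs3)ccc12`, 93000 nM
compound 3, `Cc1c(Cc2ccc(C(C)(C)C)cc2)c(=O)oc2cc(OCC(O)CN3CCC(C(N)=O)CC3)ccc12`, 14700 nM

All three share one core and differ either at the amine end of the side chain or in the benzyl group. In an ADME assay on A549 cells (Homo sapiens) for cytotoxicity, read by CellTiter-Glo (on this read-out lower numbers stand for higher toxicity in this test and higher numbers for lower toxicity in this test), compound 3 gives the lowest number of the three, beyond the scatter from both compound 1 and compound 2. Within the data shown here, the only single-point step measured so far is a 1.7-fold higher number from compound 1 to compound 2 (0.24 log units; within the scatter), a change at the amine nitrogen rather than in the benzyl group.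

Compound 4, `Cc1cc(F)ccc1Cc1c(C)c2ccc(OCC(O)CN3CCC(C(N)=O)CC3)cc2oc1=O`, is to be measured in this assay. It differs from compound 3 in one place: 4-fluoro-2-methylphenyl in place of 4-(tert-butyl)phenyl on a saturated chain carbon bound to an aromatic carbon. Among the measured compounds shown here, no measured step touches the benzyl group, so nothing here speaks to the size or direction of this change. Pending data, the expectation is a number close to that of compound 3, with a step of a 1.4-fold higher number from compound 3 to compound 4 (0.13 log units; within the scatter) that is estimated to stay within the scatter. Compound 4 is therefore estimated at 20000 nM, with a range from 7000 nM to 60000 nM.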

Compound 4, half-maximal cytotoxic concentration: > 100000 nM
Compound 4 ended at the assay's limit; the forecaster's own chance of this, stated with the estimate: 10%; middle value at least 5.0-fold (0.69 log units) away from the limit.
By their numbers in this assay, from the lowest: compound 3; then compounds 1 and 2 (each within the scatter of the next). At a limit, above all of these: compound 4.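

In this assay compound 4 gives > 100000 nM, which is a limit of the assay and not a number. Among these compounds, the benzyl group is thus the first place where a single change is seen to move the read-out beyond the scatter, an at least 6.8-fold higher number from compound 3 to compound 4 (0.83 log units; beyond the scatter), with 4-fluoro-2-methylphenyl in place of 4-(tert-butyl)phenyl on a saturated chain carbon bound to an aromatic carbon, whereas the one earlier step at the amine nitrogen, a 1.7-fold higher number from compound 1 to compound 2 (0.24 log units; within the scatter), stayed within it. This step gives a lower bound and not a full size: the limit of > 100000 nM in this assay, at which 1 of the 4 values shown sits.

The compounds shown do not separate the loss of tert-butyl from the gain of fluoro and methyl. From the compounds shown here alone, how a 4-methoxyphenyl or 4-chlorophenyl group would read with the amine end of compound 3 also remains open.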